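The source may hold more compounds than are shown below. What is called first, only, known or untested is meant among the compounds shown, and "the series" means these compounds.

Three compounds have numbers in a functional assay on HL-60 cells (Homo sapiens) for antiproliferative activity, read by MTT assay, with a stated time of 72 h; on this read-out higher numbers stand for weaker inhibition and lower numbers for stronger inhibition:

Compound 1 `CC(C)(C)c1ccc(OCCCON2C(N)=NC(N)=NC23CCSCC3)cc1`: 280 nM
Compound 2 `NC1=NC2(CCOCC2)N(OCCCOc2cccc(Cl)c2Cl)C(N)=N1`: 440 nM
Compound 3 `NC1=NC2(CCOCC2)N(OCCCOc2cc(Cl)c(Cl)cc2Cl)C(N)=N1`: 2360 nM

Compound 1 has the lowest of these three numbers. Its nearest neighbour is compound 2, whose value sits within the scatter of compound 1, so no order between the two can be claimed. Compound 3 lies clearly further away, beyond the scatter.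

Compound 4 `COc1ccc(OCCCON2C(N)=NC(N)=NC23CCSCC3)cc1` is not yet measured. It keeps the core of compound 1 and differs only on the aryl ring: methoxy in place of tert-butyl on an aromatic carbon

Among the measured compounds shown here, only one measured step is available, and it is indirect. a 5.4-fold higher number from compound 2 to compound 3 (0.73 log units; beyond the scatter) shows that changing the pattern of chlorines on the aryl ring of a related core shifts the number by a modest amount. It does not involve a methoxy or a tert-butyl, and it sits on a different core, so it only shows that this part of the molecule is not indifferent to change. The difference between compound 1 and compound 4 is a swap of one aryl substituent, which by that single precedent would be expected to move the number by a modest amount, more likely upward than downward, but a step within the scatter cannot be excluded. For compound 4 the estimate is 600 nM, within 200 nM to 2000 nM, which would mean an expected step of a 2.1-fold higher number from compound 1 to compound 4 (0.33 log units; beyond the scatter).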

Compound 4, half-maximal inhibitory concentration: 500 nM
For compound 4 the middle estimate is 1.2-fold (0.08 log units) above the measured one; low and high end bracket the measured number.
By their numbers in this assay, from the lowest: compounds 1, 2 and 4 (each within the scatter of the next); then compound 3.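

In this assay, putting methoxy in place of tert-butyl on the aromatic carbon gives a 1.8-fold higher number from compound 1 to compound 4 (0.25 log units; within the scatter), so the two groups cannot be told apart at this position on this core. The earlier step involved only a change in the pattern of chlorines on a different core, whereas this pair gives a direct comparison on the core of compound 1. It shows that this place accepts quite different groups with no difference that stands clear of the scatter, even though methoxy has fewer heavy atoms than tert-butyl, contains oxygen, and carries a hydrogen-bond acceptor that tert-butyl lacks. No supporting measurement bears on this result, so it gives no explanation for the outcome.

The compounds shown leave open whether a charged group such as a carboxylic acid or an amine at this place would keep the number in the same range, or would move it clearly. They also leave open whether a chlorine here on the core of compound 1 would produce a step as large as a 5.4-fold higher number from compound 2 to compound 3 (0.73 log units; beyond the scatter).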